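Methoxy for Methylamino on the Ethynyl Nucleoside Core

The compounds below may be only part of what the source reports. "The series", "measured", "known", "first", "only" and "open" are said of these compounds alone.

Compound 3 `C#Cc1cn([C@@H]2O[C@H](CO)[C@@H](O)[C@H]2O)c2ncnc(NC)c12` stands at the edge of what the assay reports: in an ADME assay on MRC5 cells (Homo sapiens), read by MTT assay, with a stated time of 72 h (on this read-out higher numbers stand for weaker inhibition and lower numbers for stronger inhibition), compound 3 gives > 100000 nM, which is a limit rather than a number (the limit of > 100000 nM in this assay, at which 1 of the 3 values shown sits). Compound 2 `C#Cc1cn([C@@H]2O[C@H](CO)[C@@H](O)[C@H]2O)c2ncnc(C)c12`, the methyl analogue, gives 1440 nM in this assay, and the step of an at least 69-fold higher number from compound 2 to compound 3 (1.84 log units; beyond the scatter) is large. Compound 1 `COc1ncnc2c1c(-c1ccsc1)cn2[C@@H]1O[C@H](CO)[C@@H](O)[C@H]1O`, which carries a methoxy group on the same carbon but a thiophenyl rather than the ethynyl, gives 75300 nM in this assay. Compound 4 `C#Cc1cn([C@@H]2O[C@H](CO)[C@@H](O)[C@H]2O)c2ncnc(OC)c12` arises from compound 3 by methoxy in place of methylamino on an aromatic carbon. Only the methyl-to-methylamino step bears directly on this change, and the value of compound 1 is the sole pointer for a methoxy group on this carbon. Compound 4 is expected to give about 60000 nM, within 15000 nM to 100000 nM, an expected step of an at least 1.6-fold lower number from compound 3 to compound 4 (0.22 log units; that floor lies within the scatter).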

Compound 4, half-maximal inhibitory concentration: > 100000 nM
Compound 4: no number, only a limit; the forecaster's own chance of this, stated with the estimate: 35%; middle value at least 1.6-fold (0.22 log units) away from the limit.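

In this assay compound 4, like compound 3, sits at a limit and not at a number, so the step between them cannot be read, and methoxy joins methylamino at the same edge of the read-out: the limit of > 100000 nM in this assay, at which 2 of the 4 values shown sit.

With methoxy in place of methyl, the change gives an at least 69-fold higher number from compound 2 to compound 4 (1.84 log units; beyond the scatter), so among these ethynyl compounds only the methyl of compound 2 gives a number. With ethynyl in place of thiophen-3-yl, the change gives an at least 1.3-fold higher number from compound 1 to compound 4 (0.12 log units; that floor lies within the scatter), which leaves the effect of that swap unsettled.

On these data alone, how far methoxy and methylamino each lie past the limit stays open. So does whether an ethyl group or a chlorine on this carbon would stay near methyl or reach the limit.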